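This account rests on a few compounds, and the source may have more. Where it says the series, first, only, none or still open, it means among the compounds named here.

Values measured in a functional assay on HCT-116 cells (Homo sapiens) for antiproliferative activity, read by MTT assay, with a stated time of 72 h; on this read-out higher numbers stand for weaker inhibition and lower numbers for stronger inhibition:

- compound 1 `COc1ncc(-c2ccc3c(c2)N(c2ccc(F)cc2)C(=O)CO3)cc1NS(=O)(=O)c1ccc(F)cc1` gives > 40000 nM as a limit
- compound 2 `O=C1COc2ccc(-c3cnc(Cl)c(NS(=O)(=O)c4ccc(F)cc4)c3)cc2N1c1ccc(F)cc1` gives 34200 nM as a number
- compound 3 `COc1cccc(N2C(=O)COc3ccc(-c4cccc(NS(=O)(=O)c5ccc(F)cc5)c4)cc32)c1` gives > 40000 nM as a limit

Among the measured compounds shown here, compound 2 is the only member of the series with an actual number. Compound 1 and compound 3 stand at the limit of > 40000 nM in this assay, at which 2 of the 3 values shown sit, and give no number.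

The next member is compound 4 `O=C1COc2ccc(-c3cnc(Cl)c(NS(=O)(=O)c4ccc(F)cc4)c3)cc2N1C1CC1`, and the change is cyclopropyl in place of 4-fluorophenyl on an amide-type nitrogen in a ring with cyclopropyl in place of 4-fluorophenyl on an amide-type nitrogen in a ring. For the measured compounds named here, the one measured step is an at least 1.1-fold lower number from compound 1 to compound 2 (0.06 log units; that floor lies within the scatter) and it concerns chloro in place of methoxy on an aromatic carbon, not that nitrogen. Going by the values given here, no measured step touches the group now being exchanged, so the data give no size for this change. No step beyond the scatter is therefore expected in this assay, and a reading at the limit remains quite possible. The expected result is a 1.2-fold lower number from compound 2 to compound 4 (0.09 log units; within the scatter) as the estimated step. For compound 4 the estimated value is 28000 nM with an expected range from 7000 nM to 40000 nM as the likely span.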

Compound 4, half-maximal inhibitory concentration: 12400 nM
The estimate for compound 4 lay 2.3-fold (0.35 log units) above the measured number, and the stated range covers the measured number.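

In this assay, among the compounds shown here, cyclopropyl in place of 4-fluorophenyl on the amide-type nitrogen in a ring gives a 2.8-fold lower number from compound 2 to compound 4 (0.44 log units; beyond the scatter), the first measured step at this position and the first that is beyond the scatter. For this pair, the six-membered aromatic ring on that nitrogen is not needed to keep the activity, and the smaller cyclopropyl with fewer heavy atoms gives the lower number. The series still sits close to the top of the measurable range, and compound 4 gives only 12400 nM. Limit readings are still common: the limit of > 40000 nM in this assay, at which 2 of the 4 values shown sit.

On these data alone, whether the step extends to other groups on this nitrogen, such as methyl, isopropyl or a longer alkyl chain, remains open. Also open, as far as these compounds go, is whether cyclopropyl gives a comparable step with methoxy in place of chloro on the aromatic carbon.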